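The source may report more compounds than this note shows. Statements on the series, on what has been measured and on what is new or still open speak of the compounds shown alone.

In a functional assay on MCF7 cells (Homo sapiens) for antiproliferative activity, read by MTT assay, with a stated time of 48 h (a higher number here means a weaker inhibitor, a lower number a stronger inhibitor), three compounds built on one shared core have been measured so far. Compound 1 `COc1ccc(-c2c(Nc3ccc(C)cc3)c3ccccc3oc2=O)cc1` gives 65300 nM. Compound 3 `COc1ccc(-c2c(Nc3cccc(C(F)(F)F)c3)c3ccccc3oc2=O)cc1` gives 21600 nM, and the change shows a 3.0-fold lower number from compound 1 to compound 3 (0.48 log units; beyond the scatter). Compound 2 `COc1ccc(-c2c(Nc3ccc(NC(C)=O)cc3)c3ccccc3oc2=O)cc1` reads > 100000 nM, which is a limit of the assay and not a number. Its two steps are an at least 1.5-fold higher number from compound 1 to compound 2 (0.18 log units; that floor lies within the scatter) and an at least 4.6-fold lower number from compound 2 to compound 3 (0.66 log units; beyond the scatter).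

Compound 4 `COc1ccc(-c2c(Nc3ccc(NC(C)=O)cc3)c3ccc(OC)cc3oc2=O)cc1` keeps the acetamido group of compound 2 and changes the core instead: methoxy in place of hydrogen on an aromatic carbon. In words, this is methoxy in place of hydrogen on an aromatic carbon, on a six-membered aromatic ring of carbon only that is part of a fused or bridged system of two rings.

All three measured steps change the group on the nitrogen, and none touches this carbon, so they offer only a rough sense of size. The largest of them, an at least 4.6-fold lower number from compound 2 to compound 3 (0.66 log units; beyond the scatter), comes from a different kind of change. No step beyond the scatter is therefore expected in this assay, and compound 4 may again report only a limit. The expected result is an at least 1.1-fold lower number from compound 2 to compound 4 (0.04 log units; that floor lies within the scatter). Compound 4 is estimated at 90000 nM, with an expected range from 35000 nM to 200000 nM.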

Compound 4, half-maximal inhibitory concentration: 85800 nM
For compound 4 the middle estimate is 1.0-fold (0.02 log units) above the measured one; low and high end bracket the measured number.
By their numbers in this assay, from the lowest: compound 3; then compounds 1 and 4 (each within the scatter of the next). At a limit, above all of these: compound 2.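

Compound 4 is the first compound shown with a change on the shared core instead of on the group at the nitrogen, and in this assay it gives a measured number, whereas compound 2 gives only a limit. Methoxy in place of hydrogen on this aromatic carbon, a position para to a fused ring, gives an at least 1.1-fold lower number from compound 2 to compound 4 (0.06 log units; that floor lies within the scatter), so this change on an acetamido compound shows only a floor and no step beyond the scatter can be claimed. The true size of the step stays unknown because compound 2 stands at a limit of the assay and not at a number: the limit of > 100000 nM in this assay, at which 1 of the 4 values shown sits.

The compounds shown carry methoxy at this carbon only together with the acetamido group, so it remains open whether the same change would move the number in the 4-methylphenyl compound 1 or the 3-(trifluoromethyl)phenyl compound 3. Going by these compounds, it also remains open how a hydroxyl group, an amine or a longer alkoxy chain at this same carbon would compare with methoxy or with hydrogen.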